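The compounds below may be only part of what the source reports. "The series", "measured", "known", "first", "only" and "open" are said of these compounds alone.

Measured in a functional assay on K562 cells (Homo sapiens) for cytotoxicity, read by sulforhodamine B assay; on this read-out lower numbers stand for stronger inhibition of growth and higher numbers for weaker inhibition of growth:
- compound 1 `CC1=CC[C@@H]([C@@](C)(O)CCCC(C)(C)NC(=S)NN)CC1`: 380 nM
- compound 2 `CC1=CC[C@@H]([C@@](C)(O)CCCC(C)(C)NC(=S)N/N=C\c2ccc([N+](=O)[O-])cc2)CC1`: 9560 nM
- compound 3 `CC1=CC[C@@H]([C@@](C)(O)CCCC(C)(C)NC(=S)N/N=C\c2ccccc2Cl)CC1`: 4110 nM

Among these three, compound 3 holds the middle place. Its number is the second highest, with compound 2 above it and compound 1 well below it in this assay.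

The next compound to consider is compound 4 `CC1=CC[C@@H]([C@@](C)(O)CCCC(C)(C)NC(=S)N/N=C\c2ccc(Cl)cc2)CC1`, which has not been measured yet. It differs from compound 3 by one change: 4-chlorophenyl in place of 2-chlorophenyl on a carbon with a double bond to nitrogen. In words, 4-chlorophenyl stands in place of 2-chlorophenyl on a carbon with a double bond to nitrogen, so the same atoms are simply joined differently.

Two measured steps offer guidance. The large one, an 11-fold higher number from compound 1 to compound 3 (1.03 log units; beyond the scatter), adds the whole ring-bearing group, so it says little about moving a chlorine within that group. Among the measured compounds shown here, the closer guide is a 2.3-fold lower number from compound 2 to compound 3 (0.37 log units; beyond the scatter), a modest step and the only measured swap of one ring group for another at this place. Compound 4 keeps the chlorine of compound 3 and carries its group at the 4 position, as in the 4-nitrophenyl of compound 2. A small rise at most therefore seems likely, with no step beyond the scatter.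

The expected step is a 1.3-fold higher number from compound 3 to compound 4 (0.13 log units; within the scatter).

For compound 4 the estimate is 5500 nM, with an expected range from 2500 nM to 11000 nM.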

Compound 4, concentration for total growth inhibition: 730 nM
For compound 4 the middle estimate is 7.5-fold (0.88 log units) above the measured one; the measured number lies below the stated range.
By their numbers in this assay, from the lowest: compounds 1 and 4 (each within the scatter of the next); then compound 3; then compound 2.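

In this assay, moving the chlorine while the atoms stay the same gives a 5.6-fold lower number from compound 3 to compound 4 (0.75 log units; beyond the scatter) and so shows that, on this ring, where the chlorine sits matters and not only that a chlorine is present. The group on the ring matters as well: chloro in place of nitro on an aromatic carbon gives a 13-fold lower number from compound 2 to compound 4 (1.12 log units; beyond the scatter) and is a larger change than moving the chlorine. Until now both compounds carrying the ring-bearing group had much higher numbers than compound 1, but a 1.9-fold higher number from compound 1 to compound 4 (0.28 log units; within the scatter) means that compound 4 goes against that pattern, so adding this group need not cost growth inhibition in this assay.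

No measurement here explains why these small changes in the ring group shift the number so much. Whether 4-methoxyphenyl, 4-aminophenyl or plain phenyl on the same carbon would give numbers closer to compound 4 or to compound 2 remains open, so the three ring groups shown do not yet amount to a general rule for this position.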